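From furan-3-yl to ethynyl on a shared core

The compounds below may be only part of what the source reports. "The series", "measured", "known", "first", "only" and "open" are said of these compounds alone.

Compound 1 `C#Cc1cn([C@@H]2O[C@H](CO)[C@@H](O)[C@H]2O)c2ncnc(NC)c12`: > 20000 nM
Compound 2 `CN(C)c1ncnc2c1c(-c1ccoc1)cn2[C@@H]1O[C@H](CO)[C@@H](O)[C@H]1O`: > 20000 nM

In a functional assay on HCT-116 cells (Homo sapiens), read by MTT assay, with a stated time of 72 h (a higher number here means a weaker inhibitor, a lower number a stronger inhibitor), compound 2 gives > 20000 nM, which is a limit of the assay and not a number. Compound 1 also gives only a limit, > 20000 nM. Compound 3 `C#Cc1cn([C@@H]2O[C@H](CO)[C@@H](O)[C@H]2O)c2ncnc(N(C)C)c12` has not yet been measured, and it carries ethynyl in place of furan-3-yl on an aromatic carbon. The estimated move, a number no higher from compound 2 to compound 3 (the limit leaves the size open), is expected to stay within the scatter in this assay, with no clear direction, and this expectation rests on (the limit of > 20000 nM in this assay, at which 2 of the 2 values shown sit). Compound 3 is expected at 20000 nM, with an estimated range from 6000 nM to 50000 nM.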

Compound 3, half-maximal inhibitory concentration: 290 nM
Compound 3: middle estimate off by 69-fold (1.84 log units), on the high side; measured number below the stated range.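

In this assay, the group on this aromatic carbon proves decisive: ethynyl in place of furan-3-yl gives an at least 68-fold lower number from compound 2 to compound 3 (1.83 log units; beyond the scatter). Ethynyl alone does not suffice, since methyl in place of hydrogen on a nitrogen on an aromatic ring gives an at least 68-fold lower number from compound 1 to compound 3 (1.83 log units; beyond the scatter). Compound 1 also carries ethynyl and gives > 20000 nM, which is a limit of the assay.

As far as these compounds go, whether a nitrile or a longer alkyne chain on this carbon would keep the low number of compound 3 remains open. The full size of both steps also stays open, as both start from a limit: the limit of > 20000 nM in this assay, at which 2 of the 3 values shown sit.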